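Removing the (phenoxymethyl)carbonyl group from compound 2

A few compounds are considered here, and "the series" means these few. Any claim that something is new, unique, unknown or untested is made for them only; others in the source may bear on it.

Two compounds in this series carry numbers. In an assay on nucleic acid for inhibition of Nucleic Acid, read by fluorescence, tested at 100 uM (a higher number here means more inhibition at the concentration tested (going by the name of the read-out), a lower number less inhibition), compound 1 `CCCCC(O)Cn1cc(CN(C)CC2CCCCC2)nn1` gives 47%, and compound 2 `CN(Cc1cn(C2CCCCC2OC(=O)COc2ccccc2)nn1)CC1CCCCC1` gives 37%. Compound 2 stands lowest of the two, yet its gap to compound 1 lies within the scatter, so the pair sets no order. Compound 3 `CN(Cc1cn(C2CCCCC2O)nn1)CC1CCCCC1` follows from compound 2 by hydrogen in place of (phenoxymethyl)carbonyl on an oxygen on a saturated carbon. Among the measured compounds shown here, no step between measured compounds is available; the expectation leans on compound 1, which also bears hydrogen on an oxygen on a saturated carbon and gives 47%. The step from compound 2 to compound 3 is expected to be a number 5 percentage points higher from compound 2 to compound 3 (within the scatter), not beyond the scatter. Compound 3 is estimated at 42%, from 25% to 60%.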

Compound 3, a percentage reported as inhibition, at one concentration (the size of the read-out at that concentration, not a potency): 47%
The estimate for compound 3 lay 5 percentage points below the measured number; low and high end bracket the measured number.
By their numbers in this assay, from the lowest: compounds 2, 1 and 3 (each within the scatter of the next).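

Hydrogen in place of (phenoxymethyl)carbonyl on the oxygen gives a number 10 percentage points higher from compound 2 to compound 3 (within the scatter) in this assay, so this group, with its six-membered aromatic ring, cannot be told from hydrogen at this position. Swapping 2-hydroxyhexyl for 2-hydroxycyclohexyl on the aromatic nitrogen gives no change at the digits printed from compound 1 to compound 3 (within the scatter), so the open chain and the saturated ring cannot be told apart here either. No measurement bears on why these numbers sit so close. Still open, from the compounds shown here alone, is whether any change at this position moves the number beyond the scatter, for example an amine or a carboxylic acid in place of the hydroxy group.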